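A few compounds are considered here, and "the series" means these few. Any claim that something is new, unique, unknown or untested is made for them only; others in the source may bear on it.

- Compound 1 `CN1CCN(CC#Cc2cc3ncnc(Nc4ccc(OCc5cccc(F)c5)c(Cl)c4)c3s2)CC1`: 11 uM
- Compound 2 `CCCN(CC#Cc1cc2ncnc(Nc3ccc(OCc4cccc(F)c4)c(Cl)c3)c2s1)CCC`: 26.5 uM
- Compound 3 `COCC#Cc1cc2ncnc(Nc3ccc(OCc4cccc(F)c4)c(Cl)c3)c2s1`: > 33 uM, a limit

These three compounds were read in an ADME assay on HepG2 cells (Homo sapiens) for cytotoxicity; on this read-out lower numbers stand for higher toxicity in this test and higher numbers for lower toxicity in this test. Compound 3 gives no number, only the limit > 33 uM. Compound 4 `CC(C)(C)OC(=O)N1CCC[C@H]1C#Cc1cc2ncnc(Nc3ccc(OCc4cccc(F)c4)c(Cl)c3)c2s1` departs from it as follows: 1-(tert-butoxycarbonyl)pyrrolidin-2-yl in place of methoxymethyl on a triple-bonded carbon.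

The closest evidence comes from swaps on a saturated chain carbon bound to a triple-bonded carbon: a 2.4-fold higher number from compound 1 to compound 2 (0.38 log units; beyond the scatter), an at least 3.0-fold higher number from compound 1 to compound 3 (0.47 log units; beyond the scatter) and an at least 1.2-fold higher number from compound 2 to compound 3 (0.09 log units; that floor lies within the scatter), whose floor lies within the scatter. None of these swaps places a ring directly on the triple-bonded carbon, so they guide the size of the step only loosely. A modest move to a lower number is expected, though no change beyond the scatter remains possible. The expected step is an at least 1.6-fold lower number from compound 3 to compound 4 (0.21 log units; that floor lies within the scatter). Compound 4 is estimated at 20 uM, with an expected range from 8 uM to 40 uM.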

Compound 4, half-maximal toxic concentration: > 26 uM
Compound 4: only a limit was reported; the forecaster's own chance of this, stated with the estimate: 35%; at least 1.3-fold (0.11 log units) between middle value and limit.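

In this assay compound 4 gives > 26 uM, which is a limit and not a number. With 1-(tert-butoxycarbonyl)pyrrolidin-2-yl, a ring now stands directly on the triple-bonded carbon, and the data show an at least 2.3-fold higher number from compound 1 to compound 4 (0.37 log units; beyond the scatter), a kind of change the earlier swaps did not cover. The steps from compound 2 and from compound 3 to compound 4 cannot be read.

Actual values for compound 3 and compound 4 remain open in this assay. So does whether a free pyrrolidin-2-yl, carrying a secondary amine, would read closer to compound 1 or to compound 4.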